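Carboxylic acid to tert-butyl amide on the shared core

This account rests on a few compounds, and the source may have more. Where it says the series, first, only, none or still open, it means among the compounds named here.

Compound 1, `C=CC1=C(C(=O)O)C(c2ccc(F)cc2)OC1`, is measured in a functional assay on QGY7701 cells (Homo sapiens) for cytotoxicity, read by MTT assay, with a stated time of 24 h (on this read-out lower numbers stand for stronger inhibition and higher numbers for weaker inhibition), where it reaches only the assay limit of > 100000 nM. Compound 2, `C=CC1=C(C(=O)O)C(c2ccc(OC)cc2)OC1`, likewise stops at the limit of > 100000 nM in this assay. The step from compound 1 to compound 2, a step that the two limits leave unreadable from compound 1 to compound 2, is therefore not readable, as the limit of > 100000 nM in this assay, at which 2 of the 2 values shown sit, shows. Compound 3, `C=CC1=C(C(=O)NC(C)(C)C)C(c2ccc(F)cc2)OC1`, differs from compound 1 by (tert-butyl)amino in place of hydroxy on a carbonyl carbon. Within the data shown here, no measured step bears on this change, so no direction can be drawn from the data. Compound 3 is expected to sit near the same limit, with an at least 1.1-fold lower number from compound 1 to compound 3 (0.04 log units; that floor lies within the scatter), giving an estimate of 90000 nM in a range from 20000 nM to 400000 nM.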

Compound 3, half-maximal inhibitory concentration: > 100000 nM
Compound 3: only a limit was reported; the forecaster's own chance of this, stated with the estimate: 60%; middle value at least 1.1-fold (0.04 log units) from the limit.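

In this assay, among these compounds, compound 3 stops at the limit > 100000 nM as well, so no step from compound 1 to compound 3 can be read: the limit of > 100000 nM in this assay, at which 3 of the 3 values shown sit. The compounds shown leave open whether any change on the shared core gives a measurable value in this assay at all.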